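The source may hold more compounds than are shown below. What is called first, only, known or untested is meant among the compounds shown, and "the series" means these compounds.

Measured so far:
Compound 1, `CC(=O)c1ccc(NC(=O)CN(C(=O)c2ccccc2)S(=O)(=O)c2ccc(C)cc2)cc1`, gives 18.5% in a functional assay for inhibition, read by spectrophotometry, with a stated time of 20 min, tested at 4 mg/mL; on this read-out lower numbers stand for a weaker effect and higher numbers for a stronger effect at the one concentration tested.
Compound 2, `CC(=O)c1ccc(NC(=O)C(CC(C)C)N(C(=O)c2ccccc2)S(=O)(=O)c2ccc(C)cc2)cc1`, gives 67.3% in this assay.

Compound 2 stands highest of the two numbers; its nearest neighbour is compound 1, separated by a number 48.8 percentage points higher from compound 1 to compound 2 (beyond the scatter), a step beyond the scatter. Compound 3, `CCC(C)C(C(=O)Nc1ccc(C(C)=O)cc1)N(C(=O)c1ccccc1)S(=O)(=O)c1ccc(C)cc1`, has the same atoms as compound 2, joined differently: sec-butyl in place of isobutyl on a saturated chain carbon bound to an amide-type nitrogen and a carbonyl carbon. Going by the values given here, the only measured step at this position is a number 48.8 percentage points higher from compound 1 to compound 2 (beyond the scatter), where a branched chain replaced hydrogen and the read-out rose strongly. No measured pair compares two different branched chains at this place, so the size of the isobutyl-to-sec-butyl change is not shown directly. Both groups are branched chains of the same size, and the large gain seen on going from hydrogen to isobutyl gives no reason to expect a comparable loss here. Compound 3 is therefore expected to stay near the level of its parent, the estimated step being a number 7.3 percentage points lower from compound 2 to compound 3 (within the scatter), within the scatter. Compound 3 is estimated at 60% in this assay, within a range from 35% to 80%.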

Compound 3, a percentage reported as inhibition, at one concentration (the size of the read-out at that concentration, not a potency): 41.1%
For compound 3 the middle estimate is 18.9 percentage points above the measured one, and the stated range covers the measured number.
By their numbers in this assay, from the lowest: compound 1; then compound 3; then compound 2.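

The exchange of isobutyl for sec-butyl shows that this position, a saturated chain carbon bound to an amide-type nitrogen and a carbonyl carbon, distinguishes between two branched chains with the same number of heavy atoms: in this assay the change gives a number 26.2 percentage points lower from compound 2 to compound 3 (beyond the scatter) and so lies beyond the scatter. The read-out here therefore depends on how the four carbons are joined, and not only on a branched chain being present in place of hydrogen. Sec-butyl still retains part of the gain over hydrogen, with a number 22.6 percentage points higher from compound 1 to compound 3 (beyond the scatter) as the step on that side, so both branched chains stand clear of compound 1 but to unequal degrees, and nothing at hand explains the difference between them.

What the compounds shown leave open is how the read-out responds to other groups at this place, such as a straight n-butyl chain, a methyl group, a benzyl group or a chain ending in a carboxylic acid. With only one concentration tested, they also leave open whether the order of the three compounds, which describes a stronger or weaker effect at that concentration, would hold at other concentrations.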